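This account rests on a few compounds, and the source may have more. Where it says the series, first, only, none or still open, it means among the compounds named here.

Of the compounds shown here, three have been measured in an assay on HEK293 cells for positive allosteric modulation of metabotropic glutamate receptor 3 (Rattus norvegicus), read by thallium flux, with a stated time of 2.5 min; on this read-out lower numbers stand for smaller maximal responses and higher numbers for larger maximal responses. Compound 1, `CCCC(=O)c1ccc(OCCCCOc2ccc(F)c(C(=O)O)c2)c(C)c1O`, gives 56.9%. Compound 2, `Cc1c(OCCCCOc2ccc(C(=O)O)c(Cl)c2)ccc(C(=O)CC(C)C)c1C`, gives 12%, and compound 3, `Cc1ccc(C(=O)O)cc1OCCCCOc1ccc(C(=O)CC2CCCC2)c(O)c1C`, gives 26.9%. On these numbers compound 1 stands highest: the gap to compound 3, the nearest, and the gap to compound 2, the furthest, both lie beyond the usual scatter, so compound 1 reaches the largest maximal response of the three.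

Compound 4, `Cc1c(OCCCCOc2ccc(F)c(C(=O)O)c2)ccc(C(=O)CC(C)C)c1O`, has not yet been measured. It differs from compound 1 in one place: methyl in place of hydrogen on a saturated chain carbon bound to two saturated chain carbons. Compound 1 carries the propylcarbonyl chain, compound 4 the isobutylcarbonyl chain, and everything else in the two structures is the same.

Among the measured compounds shown here, no measured pair shows this exact change, so the expectation rests on the three numbers alone. Compound 2 and compound 3, both with a branched or ring-bearing chain on the carbonyl, give smaller responses than compound 1, though each also differs from compound 1 elsewhere. A modest downward step is expected, written as a number 16.9 percentage points lower from compound 1 to compound 4 (beyond the scatter). Compound 4 is thus estimated to give 40%, within a range from 15% to 65%.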

Compound 4, largest response reached (reported as percent of maximum), in percent of the reference or control that the assay uses: 81.7%
Estimate against measurement, compound 4: 41.7 percentage points below; measured number outside the range, above it.
By their numbers in this assay, from the lowest: compound 2; then compound 3; then compound 1; then compound 4.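

Adding one methyl to the propylcarbonyl chain, which turns it into the isobutylcarbonyl chain, changes the largest response in this assay by a number 24.8 percentage points higher from compound 1 to compound 4 (beyond the scatter) and nothing else in the structure changes. Among the compounds shown here, this is the only one-place comparison available, and it shows that this saturated chain carbon bound to two saturated chain carbons is a place where a single added methyl moves the read-out upward by more than the usual scatter. The compounds shown offer no measurement that explains why the branched chain gives the larger response.

On these data alone, compound 2 and compound 3 differ from compound 4 in more than one place, so it remains open whether the same methyl would raise the response on their versions of the core. As far as these compounds go, it is also open how a longer straight chain, or an amine at the end of this chain, would compare.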